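This account rests on a few compounds, and the source may have more. Where it says the series, first, only, none or still open, it means among the compounds named here.

Compound 1 `Nc1ncnn2c([C@@H]3O[C@H](CO)[C@@H](O)[C@H]3O)cc(C#Cc3cccs3)c12`: 26600 nM
Compound 2 `Nc1ncnn2c([C@@H]3O[C@H](CO)[C@@H](O)[C@H]3O)cc(-c3ccc(F)cc3F)c12`: 93300 nM

In a functional assay on NCI-H460 cells (Homo sapiens) for antiproliferative activity, with a stated time of 72 h (a lower number here means a stronger inhibitor, a higher number a weaker inhibitor), compound 2 has the higher of the two measured numbers, at 93300 nM. Compound 3 `Nc1ncnn2c([C@@H]3O[C@H](CO)[C@@H](O)[C@H]3O)cc(-c3ccsc3)c12` carries thiophen-3-yl in place of 2,4-difluorophenyl on an aromatic carbon. Among the measured compounds shown here, only one measured step bears on this place, a 3.5-fold higher number from compound 1 to compound 2 (0.55 log units; beyond the scatter), and it was modest. A change of similar size toward a lower number is therefore expected, though one step is thin evidence. The estimated change is a 2.1-fold lower number from compound 2 to compound 3 (0.32 log units; beyond the scatter). For compound 3 the estimate is 45000 nM, expected to fall within 15000 nM to 110000 nM.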

Compound 3, half-maximal inhibitory concentration: 35600 nM
Estimate against measurement, compound 3: 1.3-fold (0.10 log units) above; low and high end bracket the measured number.
By their numbers in this assay, from the lowest: compounds 1 and 3 (each within the scatter of the next); then compound 2.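

In this assay the change to thiophen-3-yl gives a 2.6-fold lower number from compound 2 to compound 3 (0.42 log units; beyond the scatter) and so shows that, among groups attached directly by a ring at this position, the identity of the ring matters. Set against the 2-(thiophen-2-yl)ethynyl group, the same ring gives a 1.3-fold higher number from compound 1 to compound 3 (0.13 log units; within the scatter), so these two groups cannot be told apart here. Nothing available explains either step. The compounds shown leave open what an amine or a carboxylic acid on the thiophene ring would do, and whether a saturated ring such as morpholine would be accepted at this position.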